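The source may hold more compounds than are shown below. What is called first, only, known or untested is meant among the compounds shown, and "the series" means these compounds.

Compound 1 `CN1CCN(CCCCCn2c3c(c4ccccc42)C(=O)c2c[n+]([O-])c4ccccc4c2C3=O)CC1` is one of three compounds sharing a core, each carrying a side chain on an aromatic nitrogen. In a functional assay on A-375 cells (Homo sapiens) for cytotoxicity, read by MTT assay, with a stated time of 72 h (on this read-out higher numbers stand for weaker inhibition and lower numbers for stronger inhibition), compound 1 gives 1710 nM. Compound 2 `CN1CCN(CCCn2c3c(c4ccccc42)C(=O)c2c[n+]([O-])c4ccccc4c2C3=O)CC1` gives 470 nM in this assay, and compound 3 `CCCCN1CCN(CCCCn2c3c(c4ccccc42)C(=O)c2c[n+]([O-])c4ccccc4c2C3=O)CC1` gives 2150 nM. Compound 1 thus stands second highest of the three numbers: its gap to compound 3 is within the scatter, while a 3.6-fold lower number from compound 1 to compound 2 (0.56 log units; beyond the scatter) is a modest step beyond it.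

Compound 4 `O=C1c2c[n+]([O-])c3ccccc3c2C(=O)c2c1c1ccccc1n2CCN1CCCCC1` differs from compound 1 in that (piperidin-1-yl in place of 3-(4-methylpiperazin-1-yl)propyl on a saturated chain carbon, two bonds along the chain from an aromatic nitrogen). Two parts of this change can be weighed. Shortening the chain between the aromatic nitrogen and the ring amine is seen in a 3.6-fold lower number from compound 1 to compound 2 (0.56 log units; beyond the scatter), which lowered the number; the comparison a 4.6-fold higher number from compound 2 to compound 3 (0.66 log units; beyond the scatter) points the same way, though it also alters the ring substituent. Within the data shown here, no measured step covers the exchange of the piperazine ring for a piperidine ring, so that part is unknown here.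

On this basis, compound 4 is expected to show a modest lowering, a 2.4-fold lower number from compound 1 to compound 4 (0.39 log units; beyond the scatter), giving an estimated 700 nM in this assay, with a range of roughly 250 nM to 2000 nM.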

Compound 4, half-maximal inhibitory concentration: 180 nM
Compound 4: middle estimate off by 3.9-fold (0.59 log units), on the high side; measured number below the stated range.
By their numbers in this assay, from the lowest: compound 4; then compound 2; then compounds 1 and 3 (each within the scatter of the next).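

In this assay, the 2-(piperidin-1-yl)ethyl side chain of compound 4 gives the lowest number of the set, with a 2.6-fold lower number from compound 2 to compound 4 (0.42 log units; beyond the scatter), a 9.5-fold lower number from compound 1 to compound 4 (0.98 log units; beyond the scatter) and a 12-fold lower number from compound 3 to compound 4 (1.08 log units; beyond the scatter). The earlier compounds shown here all carried a substituted piperazine, so this result shows that a ring with one hetero atom, on a shorter chain, can go lower at this place than any of them, although ring and chain change together here. Nothing available explains this drop.

The compounds shown leave open how much of the step belongs to the ring and how much to the chain, and a 2-(4-methylpiperazin-1-yl)ethyl group on the same aromatic nitrogen would separate the two. On these data alone, how a morpholine ring or an open-chain dimethylamino group would read at this place also remains open.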